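The compounds below may be only part of what the source reports. "The series", "measured", "known", "first", "only" and "open" are said of these compounds alone.

Measured in an ADME assay (liver) for metabolic stability, with Liver microsome (Homo sapiens) as the target, using microsomes; a lower number here means slower removal, a higher number faster removal of the compound:
- Compound 1 `CCN(C)C(=O)c1cnc(Oc2cc(C(=O)Nc3cnc(C)cn3)cc3oc(C)cc23)cn1`: < 8 mL/min/kg, a limit
- Compound 2 `Cc1cnc(NC(=O)c2cc(Oc3cnc(C(=O)N4CCC4)cn3)c3cc(C)oc3c2)cn1`: < 9.3 mL/min/kg, a limit

Compound 2 is known only as a limit, with no number behind it. Compound 1 is likewise known only as a limit. Compound 3 `Cc1cnc(NC(=O)c2cc(Oc3cnc(C(=O)N4CCCCC4)cn3)c3cc(C)oc3c2)cn1` has piperidin-1-yl in place of azetidin-1-yl on a carbonyl carbon. Among the compounds with values here, the one measured change at this place is a step that the two limits leave unreadable from compound 1 to compound 2, so it offers no size to carry over. The step expected is an at least 1.2-fold higher number from compound 2 to compound 3 (0.11 log units; that floor lies within the scatter), a modest one toward faster removal, and this remains a loose estimate. For compound 3 the estimated value is 12 mL/min/kg, with an expected range of 7 mL/min/kg to 24 mL/min/kg.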

Compound 3, clearance: 18.2 mL/min/kg
Compound 3: the middle estimate sits 1.5-fold (0.18 log units) below what was measured; measured number inside the range.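

In this assay, within the data shown here, compound 3 gives the only number for a group on this carbonyl carbon, while compound 1 and compound 2 are known only as limits. Piperidin-1-yl gives an at least 1.9-fold higher number from compound 2 to compound 3 (0.29 log units; that floor lies within the scatter) against azetidin-1-yl and an at least 2.2-fold higher number from compound 1 to compound 3 (0.35 log units; beyond the scatter) against ethyl(methyl)amino, so the read-out does respond to the group at this place. The step from compound 1 to compound 2 cannot be read.

From the compounds shown here alone, both readable steps are floors, so their true size stays open. Also open, going by these compounds, is whether pyrrolidin-1-yl or morpholin-4-yl on this carbonyl carbon would sit with piperidin-1-yl or with azetidin-1-yl.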